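The source may hold more compounds than are shown below. What is called first, only, known or untested is meant among the compounds shown, and "the series" means these compounds.

Compound 1 `CCOC(=O)c1c(-c2c(Cl)c3ccccc3oc2=O)nn(-c2ccccc2)c1C(=O)OCC`: 100000 nM
Compound 2 `CCOC(=O)c1c(-c2c(Cl)c3cc(C)ccc3oc2=O)nn(-c2ccccc2)c1C(=O)OCC`: 228000 nM

Within the data shown here, in a functional assay on HeLa cells (Homo sapiens) for cytotoxicity, read by MTT assay, with a stated time of 48 h (on this read-out higher numbers stand for weaker inhibition and lower numbers for stronger inhibition), compound 1 gives 100000 nM, the lowest of the two numbers measured so far. Its nearest neighbour is compound 2, which in this assay gives 228000 nM; the step of a 2.3-fold higher number from compound 1 to compound 2 (0.36 log units; beyond the scatter) goes with a methyl in place of hydrogen on an aromatic carbon of the shared core.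

Compound 3 `CCOC(=O)c1c(-c2cc3ccccc3oc2=O)nn(-c2ccccc2)c1C(=O)OCC` has not yet been measured. It differs from compound 1 by hydrogen in place of chloro on an aromatic carbon. Among the measured compounds shown here, no measured step touches the chloro group, so the only step at hand, a 2.3-fold higher number from compound 1 to compound 2 (0.36 log units; beyond the scatter), is an indirect guide: it concerns a different small change on the same core and shows that such a change moved the number only modestly. With no direct evidence, a step beyond the scatter in either direction cannot be excluded, but nothing points strongly one way.

Compound 3 is therefore expected to give about 150000 nM, with a plausible range from 50000 nM to 450000 nM. This estimate means a step of a 1.5-fold higher number from compound 1 to compound 3 (0.18 log units; within the scatter), expected to stay within the scatter.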

Compound 3, half-maximal inhibitory concentration: 100000 nM
For compound 3 the middle estimate is 1.5-fold (0.18 log units) above the measured one; low and high end bracket the measured number.
By their numbers in this assay, from the lowest: compounds 1 and 3 (each within the scatter of the next); then compound 2.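

In this assay, hydrogen in place of chloro on this aromatic carbon, opposite the ring oxygen, goes with no change at the digits printed from compound 1 to compound 3 (within the scatter). Among these compounds, this is the first direct reading at this position, and it shows that, in this pair, removing the chloro group leaves the number where it was, whereas the only earlier step, on a different aromatic carbon of the shared core, was a 2.3-fold higher number from compound 1 to compound 2 (0.36 log units; beyond the scatter). Nothing available explains why the loss of the chloro group leaves the number in this place.

The compounds shown carry only chloro or hydrogen at this carbon, so what an amine or a carboxylic acid would do there remains open. Among the compounds shown here, it is also open whether hydrogen in place of chloro would leave the number equally untouched on the methyl-bearing core of compound 2, since the single pair here cannot say whether the result holds beyond the core of compound 1.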